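The source may report more compounds than this note shows. Statements on the series, on what has been measured and on what is new or still open speak of the compounds shown alone.

Three compounds share one core and differ only in the group carried on a saturated chain carbon bound to an aromatic carbon. Compound 1 `CN1CCN(Cc2nnc(-c3cc(S(N)(=O)=O)c(SCc4ccccc4)cc3Cl)o2)CC1` carries a 4-methylpiperazin-1-yl there and gives 75000 nM in a functional assay on HeLa cells (Homo sapiens) for cytotoxicity, read by MTT assay, with a stated time of 72 h; on this read-out lower numbers stand for stronger inhibition and higher numbers for weaker inhibition. Compound 2 `NS(=O)(=O)c1cc(-c2nnc(CN3CCN(c4ccccc4)CC3)o2)c(Cl)cc1SCc1ccccc1` gives 100000 nM in this assay, and compound 3 `CCOC(=O)c1cn(Cc2nnc(-c3cc(S(N)(=O)=O)c(SCc4ccccc4)cc3Cl)o2)nn1` gives 122000 nM. All three numbers sit close together: a 1.3-fold higher number from compound 1 to compound 2 (0.12 log units; within the scatter), a 1.6-fold higher number from compound 1 to compound 3 (0.21 log units; within the scatter) and a 1.2-fold higher number from compound 2 to compound 3 (0.09 log units; within the scatter), so compound 3 cannot be set apart from the other two.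

Compound 4 `NC(=O)c1cn(Cc2nnc(-c3cc(S(N)(=O)=O)c(SCc4ccccc4)cc3Cl)o2)nn1` keeps the triazolylmethyl group of compound 3 and changes only its end: amino in place of ethoxy on a carbonyl carbon, that is, ethoxycarbonyl to carbamoyl. For the measured compounds named here, no measured step touches this position. The nearest evidence is that exchanging the whole side group, as in a 1.6-fold higher number from compound 1 to compound 3 (0.21 log units; within the scatter) and a 1.2-fold higher number from compound 2 to compound 3 (0.09 log units; within the scatter), left the number within the scatter, so a smaller change at the tip of that group is expected to do likewise. For compound 4 the step of a 1.0-fold lower number from compound 3 to compound 4 (0.01 log units; within the scatter) is therefore expected to stay within the scatter. Compound 4 is estimated at 120000 nM in this assay, with a range from 60000 nM to 240000 nM.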

Compound 4, half-maximal inhibitory concentration: 75000 nM
Compound 4: middle estimate off by 1.6-fold (0.20 log units), on the high side, and the stated range covers the measured number.
By their numbers in this assay, from the lowest: compounds 1, 4, 2 and 3 (each within the scatter of the next).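

In this assay, the tip of the triazole side group now has a measured change, ethoxycarbonyl to carbamoyl, and the result is a 1.6-fold lower number from compound 3 to compound 4 (0.21 log units; within the scatter); swapping ethoxy for amino on this carbonyl carbon therefore has no readable effect on the number, even though it removes a chain and adds a hydrogen-bond donor. The new 4-carbamoyl-1H-1,2,3-triazol-1-yl group also cannot be separated from either piperazine group, with a 1.3-fold lower number from compound 2 to compound 4 (0.12 log units; within the scatter) and no change at the digits printed from compound 1 to compound 4 (within the scatter), so all four side groups shown remain indistinguishable in this read-out. Nothing measured here offers an explanation for this flat picture.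

The compounds shown leave open whether a carboxylic acid at this carbonyl carbon, or a longer chain such as butoxy in place of ethoxy, would move the number beyond the scatter. They also leave open whether a change in the shared core, rather than in this side group, would have a larger effect on the number.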